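This account rests on a few compounds, and the source may have more. Where it says the series, first, only, none or still open, it means among the compounds named here.

Working notes on the anilino and amino series of the shared core.

Compound 1 `CCCc1ccc(NC2=CC(=O)c3c(nc4n3[C@H]3OC[C@@H](O)[C@H]3OC4)C2=O)cc1` gives 6030 nM in a functional assay on HeLa cells (Homo sapiens) for inhibition, read by sulforhodamine B assay; a higher number here means a weaker inhibitor, a lower number a stronger inhibitor. Compound 2 `COc1ccc(NC2=CC(=O)c3c(nc4n3[C@H]3OC[C@@H](O)[C@H]3OC4)C2=O)cc1` has methoxy in place of propyl on an aromatic carbon. In this assay compound 2 reaches only a limit, > 8000 nM. The step is an at least 1.3-fold higher number from compound 1 to compound 2 (0.12 log units; that floor lies within the scatter), read against the limit (the limit of > 8000 nM in this assay, at which 1 of the 3 values shown sits). Compound 3 `O=C1C(N2CCCCC2)=CC(=O)c2c1nc1n2[C@H]2OC[C@@H](O)[C@H]2OC1` carries piperidin-1-yl in place of the (4-methoxyphenyl)amino group. In this assay compound 3 also sits at a limit, > 16000 nM, the weakest end of the numbers shown, at the limit (the limit of > 16000 nM in this assay, at which 1 of the 3 values shown sits). The step that the two limits leave unreadable from compound 2 to compound 3 therefore cannot be sized.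

Compound 4 `COc1ccccc1NC1=CC(=O)c2c(nc3n2[C@H]2OC[C@@H](O)[C@H]2OC3)C1=O` differs from compound 3 by (2-methoxyphenyl)amino in place of piperidin-1-yl on a double-bonded ring carbon. Both measured steps bear on it only loosely: the methoxy swap was at most modest, and the arylamino-to-piperidine step is unreadable. The return to an arylamino group suggests a value near those of compound 1 and compound 2 rather than at the higher limit. The estimated step is an at least 2.0-fold lower number from compound 3 to compound 4 (0.30 log units; that floor lies within the scatter). For compound 4 the expected value in this assay is 8000 nM, with a range from 3000 nM to 20000 nM.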

Compound 4, half-maximal inhibitory concentration: 7460 nM
For compound 4 the middle estimate is 1.1-fold (0.03 log units) above the measured one, and the stated range covers the measured number.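

At this double-bonded ring carbon, (2-methoxyphenyl)amino in place of piperidin-1-yl gives a readable number in this assay where compound 3 gave only a limit, and the step is an at least 2.1-fold lower number from compound 3 to compound 4 (0.33 log units; beyond the scatter), the only step among these compounds that lies beyond the scatter. Moving the methoxy on the phenyl ring of the amine nitrogen shows no readable change, with an at least 1.0-fold lower number from compound 2 to compound 4 (0.03 log units; that floor lies within the scatter), although that step rests on a limit and gives only a floor. Exchanging 4-propylphenyl for 2-methoxyphenyl on the same nitrogen gives a 1.2-fold higher number from compound 1 to compound 4 (0.09 log units; within the scatter), so the arylamino compounds with a number are not told apart.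

The step between compound 2 and compound 3 stays unreadable, since both are limits. Open, as far as these compounds go, is whether a carboxylic acid or an aminomethyl group on the phenyl ring, or a chain longer than propyl, would move the number beyond the scatter.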